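From 1H-pyrazol-1-yl to pyridin-3-yl on the shared core

This account rests on a few compounds, and the source may have more. Where it says the series, first, only, none or still open, it means among the compounds named here.

In a functional assay on CWR22R cells (Homo sapiens) for antiproliferative activity, read by CCK-8 assay, with a stated time of 6 days (a lower number here means a stronger inhibitor, a higher number a weaker inhibitor), compound 3 (`CCN(c1ccc(C#N)c(Cl)c1)c1cc(-n2cccn2)ccc1C`) reports only a limit (> 30000 nM), not a number. Compound 1 (`CCN(c1ccc(C#N)c(Cl)c1)c1cc(-c2ccco2)ccc1C`), with furan-2-yl, also reports only a limit (> 30000 nM). Compound 2 (`CCN(c1ccc(C#N)c(Cl)c1)c1cc(-c2c[nH]nc2C)ccc1C`), with 3-methyl-1H-pyrazol-4-yl, alone gives a number (5380 nM).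

Compound 4 (`CCN(c1ccc(C#N)c(Cl)c1)c1cc(-c2cccnc2)ccc1C`) carries pyridin-3-yl in place of the 1H-pyrazol-1-yl of compound 3, on an aromatic carbon: pyridin-3-yl in place of 1H-pyrazol-1-yl on an aromatic carbon.

Within the data shown here, all the measured steps change this same group. They show an at least 5.5-fold lower number from compound 1 to compound 2 (0.74 log units; beyond the scatter), then an at least 5.5-fold higher number from compound 2 to compound 3 (0.74 log units; beyond the scatter), and also a step that the two limits leave unreadable from compound 1 to compound 3. So one group has moved the number beyond the scatter, while two others leave it at the limit. Compound 4 may therefore also end at a limit, given (the limit of > 30000 nM in this assay, at which 2 of the 3 values shown sit). A modest move towards a lower number in this assay is nonetheless expected, and the estimated step is an at least 2.1-fold lower number from compound 3 to compound 4 (0.33 log units; beyond the scatter). For compound 4 the estimate is 14000 nM, with an expected range from 5000 nM to 30000 nM.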

Compound 4, half-maximal inhibitory concentration: 2000 nM
For compound 4 the middle estimate is 7.0-fold (0.85 log units) above the measured one, and the stated range ends above it.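

In this assay, compound 4 shows that a six-membered aromatic ring at this position, meta to a large group and para to a methyl group, can outdo all three five-membered rings shown, making compound 4 the strongest of the four. Among these compounds, its gain over the only other measurable compound is a 2.7-fold lower number from compound 2 to compound 4 (0.43 log units; beyond the scatter), so the position can give a number well below that of compound 2. The other two steps are an at least 15-fold lower number from compound 3 to compound 4 (1.17 log units; beyond the scatter) and an at least 15-fold lower number from compound 1 to compound 4 (1.17 log units; beyond the scatter), and both are minimum sizes only: the limit of > 30000 nM in this assay, at which 2 of the 4 values shown sit.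

With pyridin-3-yl as the only six-membered ring shown, ring size cannot be separated from the place of the ring nitrogen. Going by these compounds, whether phenyl or pyridin-4-yl would do as well, or whether a methyl group on the pyridine ring would change the number, remains open.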